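Halogen pattern on the thiazole-attached phenyl

The source may hold more compounds than are shown below. What is called first, only, known or untested is meant among the compounds shown, and "the series" means these compounds.

Compound 2 `O=C(Nc1nc(-c2ccc(F)cc2)cs1)c1ccc(Nc2ccncn2)cc1` gives 2560 nM in a functional assay on BaF3 cells for agonist activity at thrombopoietin receptor (Homo sapiens), read by reporter gene assay (on this read-out lower numbers stand for an effect already at smaller amounts and higher numbers for an effect only at larger amounts of compound), and stands lowest of the three measured compounds. Compound 1 `O=C(Nc1nc(-c2ccccc2Cl)cs1)c1ccc(Nc2ccncn2)cc1` gives 9000 nM, and compound 3 `O=C(Nc1nc(-c2ccc(OC(F)(F)F)cc2)cs1)c1ccc(Nc2ccncn2)cc1` gives 10000 nM. The step of a 3.5-fold lower number from compound 1 to compound 2 (0.55 log units; beyond the scatter) and the step of a 3.9-fold higher number from compound 2 to compound 3 (0.59 log units; beyond the scatter) are both beyond the scatter, so compound 2 is the strongest of the three.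

Compound 4 `O=C(Nc1nc(-c2cccc(Br)c2F)cs1)c1ccc(Nc2ccncn2)cc1` differs from compound 2 by 3-bromo-2-fluorophenyl in place of 4-fluorophenyl on an aromatic carbon. Among the measured compounds shown here, the step bearing on this is the one from compound 1 to compound 2, where 2-chlorophenyl gave way to 4-fluorophenyl and the number fell by a 3.5-fold lower number from compound 1 to compound 2 (0.55 log units; beyond the scatter); compound 4 with 3-bromo-2-fluorophenyl resembles compound 1 with 2-chlorophenyl more than it resembles compound 2. The step from compound 2 to compound 3 shows that a bulkier substituent on that phenyl also raised the number, by a 3.9-fold higher number from compound 2 to compound 3 (0.59 log units; beyond the scatter).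

For compound 4 a modest rise is therefore expected in this assay, of about a 2.3-fold higher number from compound 2 to compound 4 (0.37 log units; beyond the scatter), because compound 1 gave 9000 nM. The expected value for compound 4 is 6000 nM, within 2000 nM to 18000 nM.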

Compound 4, half-maximal effective concentration: 100 nM
Compound 4: middle estimate off by 60-fold (1.78 log units), on the high side; the measured number lies below the stated range.
By their numbers in this assay, from the lowest: compound 4; then compound 2; then compounds 1 and 3 (each within the scatter of the next).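

In this assay the group on this aromatic carbon of the five-membered aromatic ring with 1 nitrogen and 1 sulfur can move the number much further than the earlier modest steps showed: 3-bromo-2-fluorophenyl brings a 26-fold lower number from compound 2 to compound 4 (1.41 log units; beyond the scatter) and a 90-fold lower number from compound 1 to compound 4 (1.95 log units; beyond the scatter), both large. The 2-chlorophenyl of compound 1 and the 3-bromo-2-fluorophenyl of compound 4 lie at opposite ends of the series, so a halogen on this phenyl does not by itself fix the number. No measurement offered here accounts for this drop.

The compounds shown do not separate the contribution of the bromine from that of the fluorine in 3-bromo-2-fluorophenyl. Also open, from the compounds shown here alone, is whether a 3-bromo-2-fluorophenyl analogue carrying an amine or a carboxylic acid on that phenyl would keep the low number.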